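Phenoxy to Chloro at a Cytotoxicity Limit

The source may report more compounds than this note shows. Statements on the series, on what has been measured and on what is new or still open speak of the compounds shown alone.

Compound 1 `CC(C)N(Cc1cccc(OCCCCCC(=O)O)c1)C(=O)c1ccc(-c2cccc(Oc3ccccc3)c2)cc1`, compound 2 `COc1ccc(F)c(-c2ccc(C(=O)N(Cc3cccc(OCCCCCC(=O)O)c3)C(C)C)cc2)c1` and compound 3 `CCOC(=O)CCCCCOc1cccc(CN(C(=O)c2ccc(-c3cccc(Oc4ccccc4)c3)cc2)C(C)C)c1` share one amide core and were all tested in an ADME assay on HepG2 cells (Homo sapiens) for cytotoxicity, read by CellTiter-Glo and resazurin assay, with a stated time of 72 h; a lower number here means that less compound is needed, a higher number that more compound is needed for the effect. In this assay compound 1 gives > 18700 nM, a limit of the assay rather than a number. Compound 2 gives > 26000 nM, again a limit. Compound 3 gives > 26000 nM, also a limit. Compound 3 thus stands at the higher of the two limits shown, shared with compound 2 (the limit of > 26000 nM in this assay, at which 2 of the 3 values shown sit), while compound 1 sits at the other (the limit of > 18700 nM in this assay, at which 1 of the 3 values shown sits). Among the compounds with values here, the one single-change step among the measured compounds, a step that the two limits leave unreadable from compound 1 to compound 3, ethyl in place of hydrogen on an oxygen next to a carbonyl group, has both ends at limits, so its size cannot be read.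

Compound 4 `CCOC(=O)CCCCCOc1cccc(CN(C(=O)c2ccc(-c3cccc(Cl)c3)cc2)C(C)C)c1` differs from compound 3 by chloro in place of phenoxy on an aromatic carbon. Within the data shown here, no measured step bears on exchanging a phenoxy for a chloro, and the single measured step gives no size at all. The writer therefore expects no step beyond the scatter, a step that the limit leaves unreadable from compound 3 to compound 4. Compound 4 is estimated at 30000 nM in this assay, within 10000 nM to 90000 nM, and is expected most likely to come back only as a limit.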

Compound 4, half-maximal effective concentration: > 18400 nM
Compound 4 was reported as a limit (the forecaster's own chance of this, stated with the estimate: 75%); the middle value does not contradict the limit.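

In this assay compound 4 gives > 18400 nM, a limit of the assay and not a number. Compound 3 also stands at a limit, so the step between compound 3 and compound 4 cannot be read. The compounds shown leave open what half-maximal effective concentration any of compounds 1 to 4 actually has in this assay.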